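The source may report more compounds than this note shows. Statements on the series, on what has been measured and on what is new or still open speak of the compounds shown alone.

Working notes on the series, read in a functional assay on HCT-116 cells (Homo sapiens) for antiproliferative activity, read by MTT assay, with a stated time of 48 h; on this read-out lower numbers stand for stronger inhibition and higher numbers for weaker inhibition. Compound 1 `CCCCCCCC(CCO)n1cnc2c(Cl)ncnc21` gives 4160 nM, and compound 2 `CCCCCCC[C@H](CCO)n1cnc2c(Cl)ncnc21` gives 2670 nM. Among the measured compounds shown here, these two numbers lie within the scatter of each other, so compound 1 is not separated from the only other exact value in the set. Compound 3 `CCCCCCCC(CCO)n1cnc2c(N(C)C)ncnc21` gives > 50000 nM, which is a limit of the assay.

Compound 4 `CCCCCCCCCCCCC(CCO)n1cnc2c(Cl)ncnc21` differs from compound 1 by pentyl in place of hydrogen on a saturated chain carbon, eight bonds along the chain from an aromatic nitrogen. For the measured compounds named here, no measured step changes the length of this chain, so the evidence is indirect. The stereo comparison, a 1.6-fold lower number from compound 1 to compound 2 (0.19 log units; within the scatter), involves the same atoms and bonds, and what separates that pair is the fact that one of compounds 1 and 2 is drawn with a defined configuration and the other without, at the place where they differ. Replacing chloro with dimethylamino gave an at least 12-fold higher number from compound 1 to compound 3 (1.07 log units; beyond the scatter), a large step, but that is a different change at a different place and says nothing about the chain.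

The data therefore give no direction for the extension, and no shift beyond the scatter is expected in this assay, although the uncertainty is wide. The expected step is a 1.4-fold lower number from compound 1 to compound 4 (0.14 log units; within the scatter). For compound 4 the estimated value is 3000 nM, with an expected range of 800 nM to 15000 nM.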

Compound 4, half-maximal inhibitory concentration: > 50000 nM
Compound 4: a limit, no number; the forecaster's own chance of this, stated with the estimate: 10%; at least 16-fold (1.22 log units) between middle value and limit.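

Pentyl in place of hydrogen on a saturated chain carbon, eight bonds along the chain from an aromatic nitrogen, gives an at least 12-fold higher number from compound 1 to compound 4 (1.07 log units; beyond the scatter), so this place on the chain does respond to a structural change, which the earlier compounds did not show: their only chain comparison was one of drawn configuration, and it stayed within the scatter. Compound 4 gives > 50000 nM, which is a limit and not a number. The large step shown earlier lay on an aromatic carbon, so this is the first large step at the chain, but its full size cannot be read: the limit of > 50000 nM in this assay, at which 2 of the 4 values shown sit.

The compounds shown leave open how the read-out changes with intermediate groups at this carbon, such as methyl, ethyl or propyl in place of hydrogen, and so where along that range the step sets in. Also open, as far as these compounds go, is whether a chain of the same length carrying an amine or a carboxylic acid would behave as pentyl does, and whether a defined configuration matters once the chain is this long.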